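This account rests on a few compounds, and the source may have more. Where it says the series, first, only, none or still open, it means among the compounds named here.

Compound 1 `Cc1cnn(-c2ccc(C)nc2C(=O)N2CC3(CC3)C[C@H]2CNc2ccc(C(F)(F)F)cn2)c1` is the reference point of this set. In a functional assay on HEK293 cells for antagonist activity at Orexin receptor type 2 (Homo sapiens), read by FLIPR and calcium flux (on this read-out lower numbers stand for lower potency and higher numbers for higher potency (the scale is a negative logarithm)), compound 1 gives 8.3, the higher of the two numbers recorded. Compound 2 `Cc1ccnc(NC[C@@H]2CC3(CC3)CN2C(=O)c2nc(C)sc2-c2ccccc2)n1` is the nearest neighbour, and in this assay compound 2 gives 7, a gap that lies beyond the usual scatter. Compound 3 `Cc1ccc(-c2ncccn2)c(C(=O)N2CCC3(CC3)C[C@H]2CNc2ccc(Cl)cn2)c1` is recorded only as a limit of the assay: in this assay compound 3 gives < 5, and that result is one of the limit readings noted as the limit of < 5 in this assay, at which 1 of the 3 values shown sits.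

Compound 4 `Cc1ccc(-c2ccccc2)c(C(=O)N2CC3(CC3)C[C@H]2CNc2ccc(C(F)(F)F)cn2)n1` has not yet been measured in this assay. It differs from compound 1 in a single place: phenyl in place of 4-methyl-1H-pyrazol-1-yl on an aromatic carbon of a six-membered aromatic ring with 1 nitrogen, ortho to a large group, two atoms from the ring nitrogen and para to a methyl group. Among the measured compounds shown here, no measured pair in this set shows exactly this exchange, so the expectation rests on compound 1 and compound 2 alone. Compound 2, which carries a phenyl on its own core, gives 7 in this assay, well under compound 1. A modest loss is therefore expected, and the estimated step from compound 1 to compound 4 is a number 0.50 log units lower from compound 1 to compound 4 (beyond the scatter). In this assay compound 4 is expected to give about 7.8, within a range from 7 to 8.6.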

Compound 4, negative logarithm of the antagonist equilibrium constant: 8
For compound 4 the middle estimate is 0.20 log units below the measured one, within the range that was stated.
By their numbers in this assay, from the lowest: compound 2; then compounds 4 and 1 (each within the scatter of the next). At a limit, below all of these: compound 3.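

In this assay, among the compounds shown here, phenyl in place of 4-methyl-1H-pyrazol-1-yl on an aromatic carbon amounts to a number 0.30 log units lower from compound 1 to compound 4 (within the scatter), the first direct reading of this position, as the earlier compounds offered no pair differing in one place. The two groups count the same number of heavy atoms, but phenyl is a six-membered aromatic ring of carbon only and has none of the hydrogen-bond acceptors counted on 4-methyl-1H-pyrazol-1-yl, so at this position, ortho to a large group and para to a methyl group, the read-out does not separate a ring with those acceptors from one without them. Nothing measured in this set bears on why the two compounds read alike.

The compounds shown hold only this one pair for the exchange, so whether it would read the same way on another core remains open. On these data alone, it also remains open how a group of a different kind at this aromatic carbon, such as morpholine, a primary amine or a carboxylic acid, would read in this assay.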